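Chloro to methoxy: compound 3 to compound 4

The compounds below may be only part of what the source reports. "The series", "measured", "known", "first", "only" and "open" are said of these compounds alone.

Values in an ADME assay on HEK293 cells (Homo sapiens) for cytotoxicity, read by MTT assay, with a stated time of 72 h; a higher number here means a weaker inhibitor, a lower number a stronger inhibitor:
- compound 1 `COc1ccc(C(=O)N2CCN(CC(=O)N3CCN(CCCc4c[nH]c5ccccc45)CC3)CC2)cc1` gives 156000 nM
- compound 2 `O=C(CN1CCN(C(=O)c2ccccc2)CC1)N1CCN(CCCc2c[nH]c3ccc(F)cc23)CC1` gives 148000 nM
- compound 3 `O=C(CN1CCN(C(=O)c2ccc(Cl)cc2)CC1)N1CCN(CCCc2c[nH]c3ccc(F)cc23)CC1` gives 44500 nM

Compound 3 has the lowest number of the three, and its gaps to compound 1 and compound 2 both lie beyond the scatter. Compound 4 `COc1ccc(C(=O)N2CCN(CC(=O)N3CCN(CCCc4c[nH]c5ccc(F)cc45)CC3)CC2)cc1` differs from it by methoxy in place of chloro on an aromatic carbon. Among the compounds with values here, the one measured step at this place is a 3.3-fold lower number from compound 2 to compound 3 (0.52 log units; beyond the scatter), modest in size. Compound 1 also carries the 4-methoxyphenyl group and gives 156000 nM, within the scatter of compound 2. A modest rise in this assay is therefore expected, with the estimated step being a 2.7-fold higher number from compound 3 to compound 4 (0.43 log units; beyond the scatter) here. Compound 4 is estimated at 120000 nM, with an expected range from 60000 nM to 220000 nM overall.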

Compound 4, half-maximal inhibitory concentration: 141000 nM
Compound 4: middle estimate off by 1.2-fold (0.07 log units), on the low side; low and high end bracket the measured number.
By their numbers in this assay, from the lowest: compound 3; then compounds 4, 2 and 1 (each within the scatter of the next).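

In this assay, the lower number belongs to chloro alone at this aromatic carbon, with a 3.2-fold higher number from compound 3 to compound 4 (0.50 log units; beyond the scatter). Methoxy in place of hydrogen stays within the scatter, with a 1.0-fold lower number from compound 2 to compound 4 (0.02 log units; within the scatter), so among these compounds methoxy reads like hydrogen here. With the 4-methoxyphenyl group in place, fluoro on the core also stays within the scatter, with a 1.1-fold lower number from compound 1 to compound 4 (0.04 log units; within the scatter).

Nothing measured here bears on what separates chloro from methoxy. Open, on these data alone, is whether a bromo, a trifluoromethyl or an amine at this carbon falls with chloro or with methoxy.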